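Swapping Benzyl for tert-Butyl on a Shared Core

A few compounds are considered here, and "the series" means these few. Any claim that something is new, unique, unknown or untested is made for them only; others in the source may bear on it.

Compound 1, with the structure `CCCCCCCCn1cc(/C=[N+](\[O-])Cc2ccccc2)nn1`, was tested in a functional assay on MDA-MB-231 cells (Homo sapiens) for inhibition, read by MTT assay, with a stated time of 24 h; a higher number here means a weaker inhibitor, a lower number a stronger inhibitor. In this assay compound 1 gives only a limit, > 100000 nM, so no number is known for it. Compound 2, with the structure `CCCCCCCCCCn1cc(/C=[N+](\[O-])Cc2ccccc2)nn1`, differs from compound 1 by an ethyl in place of hydrogen on a saturated chain carbon, eight bonds along the chain from an aromatic nitrogen. In this assay compound 2 likewise gives only a limit, > 100000 nM. The step that the two limits leave unreadable from compound 1 to compound 2 therefore cannot be read, because both values sit at the limit of > 100000 nM in this assay, at which 2 of the 2 values shown sit.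

Compound 3, with the structure `CCCCCCCCn1cc(/C=[N+](\[O-])C(C)(C)C)nn1`, has not yet been measured. Its change from compound 1 is tert-butyl in place of benzyl on a double-bonded nitrogen. For the measured compounds named here, no measured step touches this position, and the single measured step is itself unreadable, so the two known values give no direction and no size for the change, only that both starting points lie at the limit. Compound 3 is therefore expected to give 100000 nM, within 30000 nM to 300000 nM, an expected step of a number no higher from compound 1 to compound 3 (the limit leaves the size open) that would most likely again appear only as a limit.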

Compound 3, half-maximal inhibitory concentration: 29700 nM
For compound 3 the middle estimate is 3.4-fold (0.53 log units) above the measured one, and the stated range ends above it.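

For the compounds shown here, compound 3 is the first compound here to give a true number in this assay, which makes the double-bonded nitrogen the first position where a change can be sized. Going by these compounds, putting tert-butyl in place of benzyl there, which removes the aromatic ring, gives an at least 3.3-fold lower number from compound 1 to compound 3 (0.52 log units; beyond the scatter), and the full size stays open, as compound 1 has only a limit. The step from compound 1 to compound 2 cannot be read, so the chain had revealed nothing, because both of those compounds sit at the same limit of the assay: the limit of > 100000 nM in this assay, at which 2 of the 3 values shown sit.

A single pair cannot tell whether the difference follows from losing the aromatic ring or from having the branched tert-butyl group on the nitrogen, and groups such as isopropyl or cyclohexyl at this position would help to separate the two. On these data alone, it also remains open whether tert-butyl would have a similar effect on the longer chain of compound 2, or whether an amine or a carboxylic acid at the end of the chain would shift the number in this assay.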